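Chloro to bromo on the aryl of compound 3

The compounds below may be only part of what the source reports. "The series", "measured", "known", "first", "only" and "open" are said of these compounds alone.

Measured in a functional assay on MDA-MB-231 cells (Homo sapiens) for inhibition, read by MTT assay, with a stated time of 48 h; a higher number here means a weaker inhibitor, a lower number a stronger inhibitor:
compound 1 `COc1cc(/C=C/c2ccc(NC(=O)/C=C/c3ccc(OC)c(OC)c3)cc2)cc(OC)c1` gives 7740 nM
compound 2 `COc1cc(/C=C/c2ccc(NC(=O)/C=C/c3cc(OC)c(O)c(OC)c3)cc2)cc(OC)c1` gives 7130 nM
compound 3 `COc1cc(/C=C/c2ccc(NC(=O)/C=C/c3ccc(Cl)cc3)cc2)cc(OC)c1` gives 14100 nM

Compound 3 carries the highest number of the three, yet the steps leading to it are small: a 1.8-fold higher number from compound 1 to compound 3 (0.26 log units; within the scatter) and a 2.0-fold higher number from compound 2 to compound 3 (0.30 log units; within the scatter); the other pair shows a 1.1-fold lower number from compound 1 to compound 2 (0.04 log units; within the scatter). All three sit within the scatter of one another, so no ranking follows. Compound 4 `COc1cc(/C=C/c2ccc(NC(=O)/C=C/c3ccc(Br)cc3)cc2)cc(OC)c1` differs from compound 3 by bromo in place of chloro on an aromatic carbon. Within the data shown here, no measured step swaps one halogen for another; the measured steps exchange the whole aryl group, and even those stayed within the scatter. For compound 4 in this assay the expected step is therefore a 1.2-fold lower number from compound 3 to compound 4 (0.07 log units; within the scatter), nothing beyond the scatter. Compound 4 is estimated at 12000 nM, with a range from 5000 nM to 30000 nM.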

Compound 4, half-maximal inhibitory concentration: 6160 nM
Beside the measured number, compound 4's estimate is 1.9-fold (0.29 log units) above it; the range from low to high includes it.
By their numbers in this assay, from the lowest: compounds 4, 2, 1 and 3 (each within the scatter of the next, the first and the last beyond it).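

In this assay, among these compounds, a 2.3-fold lower number from compound 3 to compound 4 (0.36 log units; beyond the scatter) is the first step to pass the scatter, and it comes from a single halogen exchange para to a large group rather than from replacing the whole aryl group. With bromo at this position, the aryl group no longer stands apart from the methoxy-bearing ones: a 1.2-fold lower number from compound 2 to compound 4 (0.06 log units; within the scatter) and a 1.3-fold lower number from compound 1 to compound 4 (0.10 log units; within the scatter) both remain within the scatter. Nothing available accounts for the halogen step.

Open, as far as these compounds go, is whether fluoro, iodo or an amine at this position would follow chloro or bromo, and whether the step from chloro to bromo would hold on a different aryl substitution pattern.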